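The compounds below may be only part of what the source reports. "The series", "measured", "known", "first", "only" and "open" are said of these compounds alone.

The measured compounds:
compound 1 `C=CCNC(=O)n1c(-c2ccc(OC)cc2)cc(=O)c2c(OC)cc(OC)cc21` gives > 20000 nM in a functional assay on HepG2 cells (Homo sapiens) for antiproliferative activity, with a stated time of 72 h (on this read-out higher numbers stand for an effect only at larger amounts of compound and lower numbers for an effect already at smaller amounts), which is a limit of the assay and not a number.
compound 2 `COc1ccc(-c2cc(=O)c3c(OC)cc(OC)cc3n2S(=O)(=O)c2c(F)c(F)c(F)c(F)c2F)cc1` gives > 34400 nM in this assay, likewise a limit of the assay.

Compound 2 therefore stands at a limit of this assay, as does the only other compound shown (the limit of > 20000 nM in this assay, at which 1 of the 2 values shown sits, (the limit of > 34400 nM in this assay, at which 1 of the 2 values shown sits)), so no ordering between the two can be drawn. Compound 3 `COc1ccc(-c2cc(=O)c3c(OC)cc(OC)cc3n2S(=O)(=O)c2ccc(Cl)cc2)cc1` differs from compound 2 in one place: 4-chlorophenyl in place of 2,3,4,5,6-pentafluorophenyl on a sulfonyl sulfur, that is, 4-chlorophenyl in place of 2,3,4,5,6-pentafluorophenyl on the sulfonyl sulfur. No step between measured compounds bears on this change, and nothing shown separates compound 1 from compound 2 in this assay. Compound 3 is expected to stay at or near the limit, with a step from compound 2 to compound 3 of a number no higher from compound 2 to compound 3 (the limit leaves the size open), which is taken as no step beyond the scatter. The estimate for compound 3 in this assay is 34400 nM, with a range from 8000 nM to 150000 nM.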

Compound 3, half-maximal effective concentration: > 34400 nM
Compound 3 gave a limit, no number; the forecaster's own chance of this, stated with the estimate: 70%; the middle value lies on the limit itself.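

In this assay compound 3 gives > 34400 nM, a limit of the assay and not a number. Compound 1 and compound 2 also stand at limits, so the steps from each of them to compound 3 cannot be read. The compounds shown leave open how far any of these changes alters the antiproliferative effect.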